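Carboxy in place of ethoxymethyl: the step to compound 4

The source may report more compounds than this note shows. Statements on the series, on what has been measured and on what is new or still open speak of the compounds shown alone.

Of the compounds shown here, three have been measured so far. In a functional assay on A549 cells (Homo sapiens) for cytotoxicity, read by sulforhodamine B assay, with a stated time of 3 days (on this read-out higher numbers stand for an effect only at larger amounts of compound and lower numbers for an effect already at smaller amounts), compound 1 `CCOCc1c(C)coc1-c1ccc2c(c1OC)CCCC2(C)C` gives 22.9 uM as the second highest of the three numbers. On one side stands compound 2 `Cc1coc(-c2ccc3c(c2O)CCCC3)c1C(=O)O` with 57 uM as a higher number. On the other side stands compound 3 `Cc1coc(-c2ccc3c(c2O)CCCC3(C)C)c1C(=O)O` with 3.3 uM as a lower number. Both gaps to compound 1 lie beyond the scatter.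

Compound 4 `COc1c(-c2occ(C)c2C(=O)O)ccc2c1CCCC2(C)C` has not yet been measured. It is compound 1 with carboxy in place of ethoxymethyl on an aromatic carbon and the rest of the structure unchanged. Compound 2 and compound 3 already carry carboxy, but they differ from compound 4 elsewhere. For the measured compounds named here, their numbers, 57 uM for compound 2 and 3.3 uM for compound 3, fall on either side of compound 1, so carboxy alone does not settle the level in this assay and no direct step is available as a guide. A small downward move within the scatter is therefore expected. The estimated step of a 1.5-fold lower number from compound 1 to compound 4 (0.18 log units; within the scatter) is accordingly modest and uncertain. For compound 4 the estimated value is 15 uM with an expected range from 4 uM to 50 uM in this assay.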

Compound 4, concentration for half-maximal effect: 53.5 uM
For compound 4 the middle estimate is 3.6-fold (0.55 log units) below the measured one; the measured number lies above the stated range.
By their numbers in this assay, from the lowest: compound 3; then compound 1; then compounds 4 and 2 (each within the scatter of the next).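

In this assay, carboxy in place of ethoxymethyl on an aromatic carbon of the five-membered aromatic ring gives a 2.3-fold higher number from compound 1 to compound 4 (0.37 log units; beyond the scatter), so this exchange can now be read directly, and with the rest of the structure unchanged it moves the effect to larger amounts of compound. Methyl in place of hydrogen on an oxygen on an aromatic ring gives the far larger a 16-fold higher number from compound 3 to compound 4 (1.21 log units; beyond the scatter), which shows that, with carboxy held in place, this single change on the oxygen weighs more in this assay than the exchange of carboxy for ethoxymethyl. No measured finding among the data shown accounts for either step.

The compounds shown leave open whether the large step on the oxygen would hold with ethoxymethyl in place of carboxy, and whether an ethyl group on that oxygen would read like methyl or like hydrogen. They also leave open how a methyl ester or a primary amide in place of carboxy would read in this assay, with either methyl or hydrogen on the oxygen.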